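Series notes: urea to thiourea change at the ring amine

This account rests on a few compounds, and the source may have more. Where it says the series, first, only, none or still open, it means among the compounds named here.

Measured so far in a functional assay on MKN-74 cells (Homo sapiens) for antiproliferative activity, with a stated time of 24 h; on this read-out lower numbers stand for stronger inhibition and higher numbers for weaker inhibition:
- compound 1 `NC(=O)c1c(NC(=O)c2ccccc2Cl)sc2c1CCN(Cc1ccccc1Cl)C2` gives 4430 nM
- compound 2 `NC(=O)c1c(NC(=O)c2ccccc2Cl)sc2c1CCN(C(=O)Nc1ccccc1Cl)C2` gives 16300 nM

Going by the values given here, compound 2 stands at the highest number of the two, with compound 1 as its only neighbour. Among the compounds with values here, the one measured step, a 3.7-fold higher number from compound 1 to compound 2 (0.57 log units; beyond the scatter), concerns the same place, the amine nitrogen in a ring of the shared core, and shows that an exchange there can move the number by a modest amount.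

Compound 3 `NC(=O)c1c(NC(=O)c2ccccc2Cl)sc2c1CCN(C(=S)Nc1ccccc1I)C2` is not yet measured. Relative to compound 2 the change is a group of 10 heavy atoms (7 carbon, 1 nitrogen, 1 sulfur, 1 iodine; one six-membered aromatic ring of carbon only) in place of a group of 10 heavy atoms (7 carbon, 1 nitrogen, 1 oxygen, 1 chlorine; one six-membered aromatic ring of carbon only), on an amine nitrogen in a ring; sulfur stands where oxygen stood and iodine where chlorine stood, while the heavy-atom count, the ring, the double bond outside aromatic rings and the donor and acceptor counts all stay the same. Within the data shown here, no measured step covers this exchange itself; the step from compound 1 to compound 2 bears on the position only, not on the group that now enters. The expectation is therefore a step of a 1.0-fold lower number from compound 2 to compound 3 (0.01 log units; within the scatter) in this assay, not beyond the scatter, in either direction. Compound 3 is estimated at 16000 nM, with a range from 5000 nM to 50000 nM.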

Compound 3, half-maximal inhibitory concentration: 2630 nM
Compound 3: the middle estimate sits 6.1-fold (0.78 log units) above what was measured; measured number outside the range, below it.
By their numbers in this assay, from the lowest: compounds 3 and 1 (each within the scatter of the next); then compound 2.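

In this assay the exchange on the amine nitrogen in a ring gives a 6.2-fold lower number from compound 2 to compound 3 (0.79 log units; beyond the scatter), so an entering group that keeps the heavy-atom count, the aromatic ring and the donor and acceptor counts of (2-chlorophenyl)carbamoyl can still shift the number beyond the scatter. The other new comparison, a 1.7-fold lower number from compound 1 to compound 3 (0.23 log units; within the scatter), lies within the scatter, so the higher number seen with (2-chlorophenyl)carbamoyl does not carry over to every group with a double bond outside aromatic rings at this position, and the entering group cannot be separated from 2-chlorobenzyl in this assay. Nothing on hand gives a measured reason for the size of this step.

Sulfur for oxygen and iodine for chlorine arrive together, so the share of each remains unresolved without the sulfur-containing group carrying chlorine and the oxygen-containing group carrying iodine. Also open, going by these compounds, is how the number responds to a fluorine, a methoxy or an amine on the aromatic ring of the entering group, or to a longer chain between that ring and the nitrogen of the group.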